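The source may report more compounds than this note shows. Statements on the series, on what has been measured and on what is new or still open speak of the compounds shown alone.

Measured compounds:
compound 1, `O=C(Nc1ccc(F)cc1)c1n[nH]cc1NC(=O)c1c(F)ccc(-c2ccc(F)nc2)c1F`: 6310 nM
compound 2, `COC(=O)c1cccc(-c2ccc(F)c(C(=O)Nc3c[nH]nc3C(=O)Nc3ccc(F)cc3)c2F)c1`: "not determined" (no result reported)

In a functional assay on A2058 cells (Homo sapiens) for antiproliferative activity, read by luminescence and CellTiter-Glo, with a stated time of 96 h (a lower number here means a stronger inhibitor, a higher number a weaker inhibitor), compound 1 gives 6310 nM. For the measured compounds named here, this is the only number in hand. Going by the values given here, for compound 2 the entry in this assay reads "not determined" (no result reported), so compound 1 stands alone, with nothing measured to set it against, and no step between measured compounds can be drawn.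

Compound 3, `NC(=O)c1ccc(-c2ccc(F)c(C(=O)Nc3c[nH]nc3C(=O)Nc3ccc(F)cc3)c2F)cn1`, has not yet been measured in this assay. It differs from compound 1 in a single place: carbamoyl in place of fluoro on an aromatic carbon. Carbamoyl thus takes the place of fluoro on the ring that carries one nitrogen, so that compound 3 bears 6-carbamoylpyridin-3-yl where compound 1 bears 6-fluoropyridin-3-yl; the shared core is otherwise untouched.

Among the compounds with values here, with no measured step to lean on, the expectation rests on compound 1 alone. The expected step of a 1.6-fold lower number from compound 1 to compound 3 (0.20 log units; within the scatter) is small, toward a somewhat lower number, and may well lie within the scatter. Compound 3 is therefore estimated at 4000 nM in this assay, with a range from 1000 nM to 15000 nM.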

Compound 3, half-maximal inhibitory concentration: 295 nM
Beside the measured number, compound 3's estimate is 14-fold (1.13 log units) above it; the measured number lies below the stated range.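

In this assay, for the compounds shown here, the exchange of fluoro for carbamoyl next to the ring nitrogen gives a 21-fold lower number from compound 1 to compound 3 (1.33 log units; beyond the scatter), the first measured step. While compound 1 stood alone, nothing showed whether this position, para to a large group, responded to change at all; this step shows that it does, and that the larger carbamoyl group, which brings a hydrogen-bond donor and a hydrogen-bond acceptor where fluoro has neither, goes with the lower number. Nothing in hand bears on what lies behind this step.

From the compounds shown here alone, a single pair cannot separate the contribution of the carbonyl from that of the amide hydrogens, so it remains open whether a nitrile, a carboxylic acid, an amine or an N-methyl carboxamide at this position would give a number like that of compound 3 or one like that of compound 1. Going by these compounds alone, no step involving compound 2 can be read, so its methyl ester on a benzene ring says nothing here about how far the result extends beyond the 6-carbamoylpyridin-3-yl group.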